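Thiophene for pyridine on the homoisoflavonoid-type core

The compounds below may be only part of what the source reports. "The series", "measured", "known", "first", "only" and "open" are said of these compounds alone.

Compound 1 `O=C1/C(=C/c2ccncc2)COc2ccccc21` is measured in an assay on BTI-TN-5B1-4 cells for inhibition of Amine oxidase [flavin-containing] B (Homo sapiens), read by fluorescence and Amplex Red, using microsomes, with a stated time of 15 min (a lower number here means a stronger inhibitor, a higher number a weaker inhibitor), and gives 12400 nM. Compound 3 `CN(C)c1ccc(/C=C2\COc3cc(Cl)cc(Cl)c3C2=O)cn1` gives 10500 nM in this assay, a number that lies within the scatter of compound 1, so the two are not told apart. Compound 2 `CN(C)c1ccc(/C=C2\COc3ccccc3C2=O)cn1` gives 213 nM, a far lower number than compound 1, well beyond the scatter. Compound 1 therefore sits at the high end of the three numbers, alongside compound 3.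

Compound 4 `O=C1/C(=C/c2ccsc2)COc2ccccc21` is not yet measured. It differs from compound 1 in one place: thiophen-3-yl in place of pyridin-4-yl on a double-bonded chain carbon bound to a double-bonded ring carbon. Among the compounds with values here, no measured pair shows this exchange, so there is no step to lean on; the only known steps concern the dimethylamino-substituted pyridine of compound 2 and the chlorines of compound 3, neither of which touches this ring swap.

For compound 4 the step of a 2.1-fold lower number from compound 1 to compound 4 (0.32 log units; beyond the scatter) is expected to be small and of uncertain direction, without a clear move beyond the scatter. Compound 4 is estimated at 6000 nM in this assay, with a range of 1500 nM to 25000 nM.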

Compound 4, half-maximal inhibitory concentration: 1730 nM
For compound 4 the middle estimate is 3.5-fold (0.54 log units) above the measured one, within the range that was stated.
By their numbers in this assay, from the lowest: compound 2; then compound 4; then compounds 3 and 1 (each within the scatter of the next).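

In this assay, the exchange of pyridin-4-yl for thiophen-3-yl on a double-bonded chain carbon bound to a double-bonded ring carbon gives a 7.2-fold lower number from compound 1 to compound 4 (0.86 log units; beyond the scatter) and so counts as a modest step beyond the scatter. Within the data shown here, this is the first single-place change read at this position, and it shows that the pyridine ring nitrogen is not required on the otherwise unsubstituted core for inhibition, with a five-membered sulfur ring giving the lower number. No measurement here accounts for the step.

Open, from the compounds shown here alone, is whether the gain depends on the sulfur or on the smaller ring, a question that phenyl, furan-3-yl and thiophen-2-yl at this position would help separate. Also open, going by these compounds, is whether thiophen-3-yl keeps its step when a dimethylamino group or chlorines are present elsewhere on the compound.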